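Chloro for methoxy on the cinnamate ester of compound 1

This account rests on a few compounds, and the source may have more. Where it says the series, first, only, none or still open, it means among the compounds named here.

compound 1 `CCOC(=O)/C=C/c1cc(OC)ccc1OC(=O)c1nc(C)c(C)nc1C`: 27.8%
compound 2 `Cc1nc(C)c(C(=O)Oc2ccc(/C=C/C(=O)O)cc2O)nc1C`: 285%

In a functional assay on EA.hy 926 cells (Homo sapiens) for cytotoxicity, read by MTT assay, with stated times of 24 h and 12 h, tested at 50 uM (on this read-out lower numbers stand for a weaker effect and higher numbers for a stronger effect at the one concentration tested), compound 1 gives 27.8%, the lower of the two numbers shown, while compound 2 gives 285%, a gap beyond the usual scatter. Compound 3 `CCOC(=O)/C=C/c1cc(Cl)ccc1OC(=O)c1nc(C)c(C)nc1C` differs from compound 1 by chloro in place of methoxy on an aromatic carbon. Among the compounds with values here, no measured pair separated by a single change is available, so the size of this step cannot be read from the data. Compound 3 is expected to give about 35%, within 10% to 80%. The expected step of a number 7.2 percentage points higher from compound 1 to compound 3 (within the scatter) is estimated to stay within the scatter.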

Compound 3, a percentage reported as activity, at one concentration (the size of the read-out at that concentration, not a potency): 33.7%
The estimate for compound 3 lay 1.3 percentage points above the measured number, within the range that was stated.
By their numbers in this assay, from the lowest: compounds 1 and 3 (each within the scatter of the next); then compound 2.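

In this assay, within the data shown here, the change from methoxy to chloro gives the first single-change step in this set, a number 5.9 percentage points higher from compound 1 to compound 3 (within the scatter), so this step does not separate the two groups. At this aromatic carbon, para to a large group, the hydrogen-bond acceptor counted for methoxy can therefore be lost without a change beyond the scatter. As far as these compounds go, whether an amine or a longer chain on this carbon would behave the same remains open. Compound 2 differs from compound 1 in more than one place, so its higher number cannot be assigned to any single change. Nothing given here explains why chloro and methoxy read alike.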